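Swapping trifluoromethyl for methyl in an antiproliferative series

A few compounds are considered here, and "the series" means these few. Any claim that something is new, unique, unknown or untested is made for them only; others in the source may bear on it.

Measured compounds:
Compound 1, `NC(=O)c1c(NC(=O)c2ccccc2C(F)(F)F)sc2c1CCN(C(=S)Nc1ccccc1Cl)C2`: 21900 nM
Compound 2, `Cc1ccccc1C(=O)Nc1sc2c(c1C(N)=O)CCN(C(=S)Nc1ccccc1Cl)C2`: 11000 nM
Compound 3, `NC(=O)c1c(NC(=O)c2ccc(C(F)(F)F)cc2)sc2c1CCN(C(=S)Nc1ccccc1Cl)C2`: 16400 nM

Of the compounds shown here, three built on one shared core have been tested in a functional assay on MKN-74 cells (Homo sapiens) for antiproliferative activity, with a stated time of 24 h; on this read-out higher numbers stand for weaker inhibition and lower numbers for stronger inhibition. Compound 1 and compound 2 differ by methyl in place of trifluoromethyl on an aromatic carbon, a change that gave a 2.0-fold lower number from compound 1 to compound 2 (0.30 log units; within the scatter). Compound 1 and compound 3 differ by 4-(trifluoromethyl)phenyl in place of 2-(trifluoromethyl)phenyl on a carbonyl carbon, which gave a 1.3-fold lower number from compound 1 to compound 3 (0.13 log units; within the scatter). Between compound 2 and compound 3 the step was a 1.5-fold higher number from compound 2 to compound 3 (0.17 log units; within the scatter). All three numbers thus lie within the scatter of one another, and none of the three can be called the strongest or weakest.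

Compound 4, `Cc1ccc(C(=O)Nc2sc3c(c2C(N)=O)CCN(C(=S)Nc2ccccc2Cl)C3)cc1`, has not yet been measured. It differs from compound 3 by methyl in place of trifluoromethyl on an aromatic carbon. Within the data shown here, this is the same kind of change as the one from compound 1 to compound 2, but not the same: in compound 1 the methyl enters ortho to a large group, whereas in compound 3 it enters para to a large group. Among the measured compounds shown here, the only guidance comes from compound 1 and compound 2, where the step was a 2.0-fold lower number from compound 1 to compound 2 (0.30 log units; within the scatter), within the scatter. Compound 4 is therefore expected to sit close to compound 3, with a step of a 1.7-fold lower number from compound 3 to compound 4 (0.24 log units; within the scatter) estimated, resting on that single earlier pair. For compound 4 a value of 9500 nM is estimated, with the likely range from 4000 nM to 25000 nM.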

Compound 4, half-maximal inhibitory concentration: 11300 nM
Compound 4: the middle estimate sits 1.2-fold (0.08 log units) below what was measured; the measured number falls inside the stated range.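

Methyl in place of trifluoromethyl on an aromatic carbon gave a 1.5-fold lower number from compound 3 to compound 4 (0.16 log units; within the scatter) in this assay, and set beside the earlier case of the same change, the two steps do not differ: the same change on two cores in this assay, a 2.0-fold lower number (0.30 log units; within the scatter) from compound 1 to compound 2 and a 1.5-fold lower number (0.16 log units; within the scatter) from compound 3 to compound 4, 1.4-fold (0.14 log units) apart, within the scatter of two such steps The two other new steps are also small, with a 1.0-fold higher number from compound 2 to compound 4 (0.01 log units; within the scatter) and a 1.9-fold lower number from compound 1 to compound 4 (0.29 log units; within the scatter), so neither the swap of trifluoromethyl for methyl nor the change from the 2-substituted to the 4-substituted phenyl separates these compounds in this assay. Among these compounds, this shows only that the change gave steps of similar size in both pairs; since each step lies within the scatter, it does not show that the change has a real effect on activity here, or that any such effect carries from one core to another, and two pairs could not establish a rule for the series in any case.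

Going by these compounds, whether a methoxy group, an amine or a carboxylic acid on that aromatic carbon would give a step beyond the scatter remains open. Also open is whether the close agreement among these four compounds would hold in other cell lines or at other exposure times.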